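Solubility notes on a benzyl-for-phenoxy swap in the series

This account rests on a few compounds, and the source may have more. Where it says the series, first, only, none or still open, it means among the compounds named here.

Measured so far:
compound 1, `COc1ccc(F)cc1CNCCCNc1ccnc2cc(Cc3ccc(F)cc3Cl)ccc12`, 4200 nM
compound 2, `COc1cccc(CNCCCNc2ccnc3cc(Cc4ccc(F)cc4Cl)ccc23)c1O`, 4200 nM

In a physicochemical assay for solubility, with a stated time of 18 h, at pH 7.4 (a higher number here means a more soluble compound, a lower number a less soluble compound), compound 1 gives 4200 nM and stands level with compound 2 at the digits shown; the one measured step, no change at the digits printed from compound 1 to compound 2 (within the scatter), shows that exchanging 2-hydroxy-3-methoxyphenyl for 5-fluoro-2-methoxyphenyl on the saturated chain carbon bound to the amine nitrogen left the read-out within the scatter.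

Compound 3, `COc1ccc(F)cc1CNCCCNc1ccnc2cc(Oc3cccc(N(C)C)c3)ccc12`, is not yet measured in this assay. It differs from compound 1 on the core rather than on the chain: 3-(dimethylamino)phenoxy in place of 2-chloro-4-fluorobenzyl on an aromatic carbon

Going by the values given here, the step from compound 1 to compound 2 touches a different part of the molecule and does not bear directly on this change; no measured pair replaces a benzyl group on the core with a phenoxy group. The expectation therefore rests on compound 1 alone, and the step of a 1.2-fold higher number from compound 1 to compound 3 (0.08 log units; within the scatter) is estimated to be small, in either direction, with wide uncertainty. For compound 3 in this assay a value of 5000 nM is expected, within 1500 nM to 20000 nM.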

Compound 3, solubility: 14500 nM
Estimate against measurement, compound 3: 2.9-fold (0.46 log units) below, and the stated range covers the measured number.
By their numbers in this assay, from the lowest: compounds 1 and 2 (each within the scatter of the next); then compound 3.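

In this assay, going by these compounds alone, the aromatic carbon on the core, meta to a fused ring and para to a fused ring, gives the first step beyond the scatter: 3-(dimethylamino)phenoxy in place of 2-chloro-4-fluorobenzyl gives a 3.5-fold higher number from compound 1 to compound 3 (0.54 log units; beyond the scatter) and is a modest change, whereas the change on the chain gave no change at the digits printed from compound 1 to compound 2 (within the scatter) and stayed within the scatter. Within the data shown here, this single pair is the only reading for this exchange, and it alters the atom joining the ring to the core, the ring substituents and the count of hydrogen-bond acceptors all at once, so it does not separate these changes from one another. No measurement on hand accounts for the higher number.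

From the compounds shown here alone, it remains open whether the step follows the oxygen link or the dimethylamino group, which an unsubstituted phenoxy or a 2-chloro-4-fluorophenoxy on the same carbon would help to separate. Going by these compounds, it is also open whether the step carries over to the 2-hydroxy-3-methoxyphenyl chain end, or how a morpholine on the phenoxy ring would compare.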